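The source may report more compounds than this note shows. Statements on the series, on what has been measured and on what is new or still open speak of the compounds shown alone.

Measured compounds:
- Compound 1, `c1ccc(-c2nc3ccc(N4CCCCCC4)nc3o2)cc1`, gives 57.9% in an assay on isolated protein for inhibition of Amine oxidase [flavin-containing] B (Homo sapiens), read by fluorescence, with a stated time of 1 h, tested at 10 uM; a lower number here means less inhibition, a higher number more inhibition at the concentration tested (going by the name of the read-out)
- Compound 2, `c1ccc(-c2nc3ccc(N4CCCCC4)nc3s2)cc1`, gives 95.5% in this assay

Going by the values given here, only two compounds carry a number here, and they differ in more than one place, so the two values can only be set side by side. Compound 2 has the highest of the two numbers; the nearest, compound 1, lies a good way lower, a gap that reaches beyond the usual scatter of repeated measurements. The number of compound 2 in this assay is therefore the higher of the two, and it lies close to the top of what a percentage of inhibition can show.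

Compound 3, `Clc1ccc(-c2nc3ccc(N4CCCCC4)nc3s2)cc1`, is not yet measured. It differs from compound 2 in one place: chloro in place of hydrogen on an aromatic carbon. Among the compounds with values here, no pair of measured compounds differing in a single place is available, so the size of such a change in this assay cannot be read from the data. With compound 2 already so high, a step from compound 2 to compound 3 of a number 3.5 percentage points lower from compound 2 to compound 3 (within the scatter) is expected, which is within the scatter and points slightly downward, mostly because the measured value of compound 2 of 95.5% leaves little room upward. Compound 3 is estimated at 92%, within a range of 78% to 99%.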

Compound 3, a percentage reported as inhibition, at one concentration (the size of the read-out at that concentration, not a potency): 84.2%
Beside the measured number, compound 3's estimate is 7.8 percentage points above it; low and high end bracket the measured number.
By their numbers in this assay, from the lowest: compound 1; then compound 3; then compound 2.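

Going by these compounds alone, compound 2 and compound 3 form the first pair that differs in only one place, so the size of a single change can now be read: going from phenyl to 4-chlorophenyl gives a number 11.3 percentage points lower from compound 2 to compound 3 (beyond the scatter) in this assay at the one concentration tested. This shows that the position on the six-membered aromatic ring of carbon only, para to a large group, is not indifferent to what sits there, although the change is modest and compound 3 still gives 84.2% in this assay. Nothing else measured here bears on why adding chloro lowers the number.

A single pair cannot show whether this step is particular to chloro, and a fluoro group, a methoxy group or an amine at the same position might move the number by a different amount or in the other direction. Going by these compounds, it is also open whether chloro elsewhere on the same ring would give a similar step, and whether the same change would act alike on the core of compound 1.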